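The source may report more compounds than this note shows. Statements on the series, on what has been measured and on what is new or still open speak of the compounds shown alone.

Measured compounds in a functional assay on HeLa cells (Homo sapiens) for cytotoxicity, read by neutral red uptake, with a stated time of 3 days; a lower number here means a stronger inhibitor, a higher number a weaker inhibitor:

- compound 1, `C[S+]([O-])c1c(F)c(N)c2c(=O)cc(-c3ccc(N)c(F)c3)oc2c1F`, gives > 100000 nM, a limit of the assay rather than a number.
- compound 2, `Nc1ccc(-c2cc(=O)c3c(N)c(F)c(N)c(F)c3o2)cc1F`, gives 19000 nM.
- compound 3, `CN(C)CCC(=O)OCc1c(F)c(N)c2c(=O)cc(-c3ccc(N)c(F)c3)oc2c1F`, gives 11000 nM.

The value of compound 1 is only a limit (the limit of > 100000 nM in this assay, at which 1 of the 3 values shown sits). Among the two real numbers, compound 3 has the lowest, but its nearest neighbour is compound 2, and the step of a 1.7-fold lower number from compound 2 to compound 3 (0.24 log units; within the scatter) lies within the scatter, so the two cannot be ordered. Compound 4, `CCCCCCOCc1c(F)c(N)c2c(=O)cc(-c3ccc(N)c(F)c3)oc2c1F`, differs from compound 3 in one place: hexyl in place of (2-(dimethylamino)ethyl)carbonyl on an oxygen on a saturated carbon.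

Among the compounds with values here, no measured step changes this part of the molecule directly. The steps of an at least 5.2-fold lower number from compound 1 to compound 2 (0.72 log units; beyond the scatter) and an at least 9.0-fold lower number from compound 1 to compound 3 (0.95 log units; beyond the scatter) both exchange the group of three heavy atoms on the aromatic carbon, and the step from compound 2 to compound 3 shows that what hangs from that carbon, once the three-atom group is gone, made no difference beyond the scatter. By the same reasoning the expected step of a 1.1-fold higher number from compound 3 to compound 4 (0.04 log units; within the scatter) is small, with no clear direction. Compound 4 is therefore estimated at 12000 nM, within a range from 4000 nM to 40000 nM.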

Compound 4, half-maximal inhibitory concentration: > 100000 nM
Compound 4: no number, only a limit; the forecaster's own chance of this, stated with the estimate: 10%; middle value at least 8.3-fold (0.92 log units) from the limit.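

Swapping the group on this oxygen does change the reading in this assay, with hexyl in place of (2-(dimethylamino)ethyl)carbonyl giving an at least 9.0-fold higher number from compound 3 to compound 4 (0.95 log units; beyond the scatter). The earlier compounds shown here showed no step beyond the scatter between two real numbers, and the same holds here only as a limit-based result: an at least 5.2-fold higher number from compound 2 to compound 4 (0.72 log units; beyond the scatter), with (hexyloxy)methyl in place of amino on an aromatic carbon. Compound 4 gives a limit rather than a number, so these steps have no known upper size, and the step between compound 1 and compound 4 cannot be read, since both stand at the same limit: the limit of > 100000 nM in this assay, at which 2 of the 4 values shown sit.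

The change removes the amine and the carbonyl together, so the compounds shown do not tell which of the two matters. An ether chain of the same kind carrying an amine, or a shorter chain such as butyl, would begin to separate these parts.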